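Ester Swap at the Carbonyl Carbon, Third Variant

This account rests on a few compounds, and the source may have more. Where it says the series, first, only, none or still open, it means among the compounds named here.

Two measured compounds share a common framework and differ only in the group attached to a carbonyl carbon of an ester. Compound 1 `COc1cc(C2Oc3cc([C@H]4Oc5cc(O)cc(O)c5C(=O)[C@@H]4O)ccc3OC2COC(=O)c2ccccc2)ccc1O` carries a phenyl group there, and in a functional assay, read by spectrophotometry, with a stated time of 30 min (on this read-out higher numbers stand for an effect only at larger amounts of compound and lower numbers for an effect already at smaller amounts), compound 1 gives 105000 nM. Compound 2 `CCOC(=O)CC(=O)OCC1Oc2ccc([C@H]3Oc4cc(O)cc(O)c4C(=O)[C@@H]3O)cc2OC1c1ccc(O)c(OC)c1` carries an (ethoxycarbonyl)methyl group in its place, and in this assay compound 2 gives 101000 nM. The step of a 1.0-fold lower number from compound 1 to compound 2 (0.02 log units; within the scatter) shows that the two numbers cannot be told apart; compound 2 stands lowest of the two, with compound 1 nearest, the gap being within the scatter.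

Compound 3 `COc1cc(C2Oc3cc([C@H]4Oc5cc(O)cc(O)c5C(=O)[C@@H]4O)ccc3OC2COC(=O)/C=C/c2ccc(C)cc2)ccc1O` has not yet been measured. Its change from compound 2 is 2-(4-methylphenyl)ethenyl in place of (ethoxycarbonyl)methyl on a carbonyl carbon. Within the data shown here, the single measured step that bears on this position is a 1.0-fold lower number from compound 1 to compound 2 (0.02 log units; within the scatter), where exchanging one ester substituent for another left the number essentially where it was. Among the measured compounds shown here, no measured compound carries an ethenyl-linked aromatic group at this place, so there is nothing to point in either direction. Compound 3 is therefore expected to show a 1.0-fold lower number from compound 2 to compound 3 (0.00 log units; within the scatter), no step beyond the scatter. As an estimate, compound 3 is expected to give about 100000 nM in this assay, within a range from 40000 nM to 250000 nM.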

Compound 3, half-maximal effective concentration: 136000 nM
The estimate for compound 3 lay 1.4-fold (0.13 log units) below the measured number, and the stated range covers the measured number.
By their numbers in this assay, from the lowest: compounds 2, 1 and 3 (each within the scatter of the next).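

In this assay, replacing (ethoxycarbonyl)methyl with 2-(4-methylphenyl)ethenyl on the carbonyl carbon gives a 1.3-fold higher number from compound 2 to compound 3 (0.13 log units; within the scatter), and replacing phenyl with the same group gives a 1.3-fold higher number from compound 1 to compound 3 (0.11 log units; within the scatter). The new group brings one six-membered aromatic ring of carbon only, joined through a double bond, and has no hydrogen-bond acceptors, whereas the (ethoxycarbonyl)methyl group it replaces has them; even so, this assay does not separate the three groups, so what the first pair suggested now holds across three quite different ester substituents. No further evidence is available to explain why these numbers stay together.

From the compounds shown here alone, what would happen with a group of another kind at this place, such as an amine, a carboxylic acid or a longer saturated carbon chain, remains open, and so does whether any such group would give a step beyond the scatter. All three compounds also keep the same ester link and the same shared core, so the part played by the ester oxygen, or by the core itself, cannot be judged from them.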